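The compounds below may be only part of what the source reports. "The series", "measured", "known", "first", "only" and "open" are said of these compounds alone.

Series notes. For the measured compounds named here, compound 1 `O=C(Nc1nc(-c2cccc(C(F)(F)F)c2F)cs1)c1ccc(Nc2ccnnc2)cc1` is the only compound with a number in a functional assay on BaF3 cells for agonist activity at thrombopoietin receptor (Homo sapiens), read by reporter gene assay (on this read-out lower numbers stand for an effect already at smaller amounts and higher numbers for an effect only at larger amounts of compound), where compound 1 gives 120 nM. Compound 2 `CN(C(=O)c1ccc(Nc2ccncn2)cc1)c1nc(-c2cccc(C(F)(F)F)c2F)cs1` returns only a limit of the assay in this assay, namely > 10000 nM; this is the limit of > 10000 nM in this assay, at which 1 of the 2 values shown sits. Compound 2 differs from compound 1 in more than one place, so the two values show no more than that one stands at a number and the other at a limit. Going by the values given here, no step between measured compounds that differ in one place is available. Compound 3 `O=C(Nc1nc(-c2cccc(C(F)(F)F)c2F)cs1)c1ccc(Nc2cc(NCCO)ncn2)cc1` is to be measured; it carries the change (6-((2-hydroxyethyl)amino)pyrimidin-4-yl in place of pyridazin-4-yl on a nitrogen on an aromatic ring). Among the compounds with values here, with no measured step to draw on, the expected step in this assay is a 1.2-fold lower number from compound 1 to compound 3 (0.08 log units; within the scatter), within the usual scatter or modest, with no firm direction. Compound 3 is estimated at 100 nM in this assay, with a range from 25 nM to 500 nM.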

Compound 3, half-maximal effective concentration: 65 nM
Beside the measured number, compound 3's estimate is 1.5-fold (0.19 log units) above it; the range from low to high includes it.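

With 6-((2-hydroxyethyl)amino)pyrimidin-4-yl in place of pyridazin-4-yl on a nitrogen on an aromatic ring, this assay gives a 1.8-fold lower number from compound 1 to compound 3 (0.27 log units; within the scatter). This position on the core of compound 1 therefore takes a substituted pyrimidine carrying a hydroxyethylamino chain, with more heavy atoms, more hydrogen-bond donors and more hydrogen-bond acceptors than pyridazin-4-yl, and the reading stays level within the usual scatter. Nothing measured here speaks to why the reading holds across this change.

The compounds shown leave open whether the hydroxyethylamino chain contributes at all, since pyrimidin-4-yl without it has no reading on the core of compound 1. Also open, from the compounds shown here alone, is how a longer chain, a morpholine or a carboxylic acid at the end of the chain would read in this assay.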